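Ketone side-chain shortening: outlook for compound 4

This account rests on a few compounds, and the source may have more. Where it says the series, first, only, none or still open, it means among the compounds named here.

Measured in an assay on HEK293 cells for positive allosteric modulation of metabotropic glutamate receptor 2 (Rattus norvegicus), read by thallium flux, with a stated time of 2.5 min; a higher number here means that more compound is needed for the effect, a lower number that less compound is needed:
compound 1 `CCCC(=O)c1ccc(OCCCCOc2ccc(F)c(C(=O)O)c2)c(C)c1O`: 74 nM
compound 2 `Cc1c(OCCCCOc2ccc(F)c(C(=O)O)c2)ccc(C(=O)CC(C)(C)C)c1O`: 208 nM
compound 3 `Cc1c(OCCCCOc2ccc(C(=O)CC(C)(C)C)c(O)c2C)cccc1C(=O)O`: 136 nM

Compound 2 gives the highest number of the three in this assay. One neighbouring gap lies within the scatter: a 1.5-fold lower number from compound 2 to compound 3 (0.18 log units; within the scatter). The other lies beyond it: a 2.8-fold higher number from compound 1 to compound 2 (0.45 log units; beyond the scatter).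

Compound 4 `CCC(=O)c1ccc(OCCCCOc2ccc(F)c(C(=O)O)c2)c(C)c1O` differs from compound 2 in one place: methyl in place of tert-butyl on a saturated chain carbon bound to a carbonyl carbon. Going by the values given here, the only step that bears on this is a 2.8-fold higher number from compound 1 to compound 2 (0.45 log units; beyond the scatter), which covers the same place in the other direction with a group only a little larger than methyl entering. Compound 4 is therefore expected to give a lower number in this assay, with a step of roughly that size: a 3.0-fold lower number from compound 2 to compound 4 (0.47 log units; beyond the scatter). Compound 4 is estimated at 70 nM, range 30 nM to 170 nM.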

Compound 4, half-maximal effective concentration: 124 nM
Compound 4: middle estimate off by 1.8-fold (0.25 log units), on the low side, and the stated range covers the measured number.
By their numbers in this assay, from the lowest: compounds 1, 4, 3 and 2 (each within the scatter of the next, the first and the last beyond it).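

In this assay methyl in place of tert-butyl gives a 1.7-fold lower number from compound 2 to compound 4 (0.22 log units; within the scatter) and hydrogen in place of methyl on the chain of compound 1 gives a 1.7-fold higher number from compound 1 to compound 4 (0.22 log units; within the scatter) so the propanoyl ketone of compound 4 cannot be told apart from either compound. Only the wider change, a 2.8-fold higher number from compound 1 to compound 2 (0.45 log units; beyond the scatter) remains beyond the scatter, so this place shows a graded range of small steps rather than one sharp break at a single chain length. No measurement shown accounts for this. Still open, from the compounds shown here alone, is whether an amine or a hydroxyl on the chain, or a cyclopropyl group in place of the chain, keeps the number in this range.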